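A few compounds are considered here, and "the series" means these few. Any claim that something is new, unique, unknown or untested is made for them only; others in the source may bear on it.

Measured so far:
- compound 1 `O=C1c2c[n+]([O-])c3ccccc3c2C(=O)c2c1c1ccccc1n2CCCCN1CCNCC1`: 540 nM
- compound 2 `CC1(C)O[C@@H](CO)[C@H](Cn2cc(Cn3c4c(c5ccccc53)C(=O)c3c[n+]([O-])c5ccccc5c3C4=O)nn2)O1`: 370 nM

Two compounds of the series have been run in a functional assay on A549 cells (Homo sapiens) for cytotoxicity, read by MTT assay, with a stated time of 72 h; a higher number here means a weaker inhibitor, a lower number a stronger inhibitor. Compound 1 gives 540 nM, compound 2 gives 370 nM. Going by the values given here, compound 1 has the higher of the two numbers, but the gap to compound 2 lies within the scatter of repeat measurements, so the two cannot be ranked against each other on this assay, and no measured step between compounds that differ in one place is available.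

Compound 3 `O=C1c2c[n+]([O-])c3ccccc3c2C(=O)c2c1c1ccccc1n2CCCN1CCC(O)CC1` is not yet measured. Relative to compound 1 the change is 4-hydroxypiperidin-1-yl in place of (piperazin-1-yl)methyl on a saturated chain carbon, three bonds along the chain from an aromatic nitrogen. The shared core and the tether from the aromatic nitrogen are otherwise kept. With no measured step of this kind in the series, the expectation rests on the two numbers shown, which sit close together, and on the modest size of the change in this assay.

For compound 3 a number in the region of compound 1 is expected, 650 nM, with a range of 250 nM to 1800 nM. The step of a 1.2-fold higher number from compound 1 to compound 3 (0.08 log units; within the scatter) is thus estimated to fall within the scatter, with no clear direction.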

Compound 3, half-maximal inhibitory concentration: 350 nM
The estimate for compound 3 lay 1.9-fold (0.27 log units) above the measured number; measured number inside the range.
By their numbers in this assay, from the lowest: compounds 3, 2 and 1 (each within the scatter of the next).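

In this assay the series now has its first comparison across one place, and a 1.5-fold lower number from compound 1 to compound 3 (0.19 log units; within the scatter) lies within the scatter, so compound 1 and compound 3 cannot be told apart. At this position, on a saturated chain carbon, three bonds along the chain from an aromatic nitrogen, 4-hydroxypiperidin-1-yl in place of (piperazin-1-yl)methyl therefore leaves no readable effect in this pair, even though the same difference also reads as 4-(piperazin-1-yl)butyl to 3-(4-hydroxypiperidin-1-yl)propyl, and so covers both the tether and the terminal ring. No measurement on these compounds bears on why the two numbers fall so close together.

With tether and terminal ring differing together, this pair cannot show whether each is without effect on its own or whether the two offset each other; that would take the piperazin-1-yl ring on the 3-carbon propyl tether, or the 4-hydroxypiperidin-1-yl ring on the butyl tether. It also leaves open how far the position accepts other end groups, such as a morpholine ring, a primary amine or a carboxylic acid, or a longer chain.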